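The source may report more compounds than this note shows. Statements on the series, on what has been measured and on what is new or still open speak of the compounds shown alone.

Measured compounds:
compound 1 `CCc1cccc2c(OC)c(-c3occ(C)c3C(=O)NC)ccc12` — > 10 ug/mL
compound 2 `CCc1cccc2c(OC)c(-c3occ(C)c3C(=O)On3nnc4ccccc43)ccc12` — > 10 ug/mL
compound 3 `CCc1cccc2c(OC(C)=O)c(-c3occ(C)c3COC(C)=O)ccc12` — > 10 ug/mL

In a functional assay on SK-BR-3 cells (Homo sapiens) for cytotoxicity, read by MTT assay, with a stated time of 72 h (a lower number here means that less compound is needed, a higher number that more compound is needed for the effect), compound 1 gives > 10 ug/mL, which is a limit of the assay and not a number. Compound 2 likewise gives only > 10 ug/mL, a limit. Compound 3 also sits at > 10 ug/mL, again a limit. Among the compounds with values here, the one step that joins two measured compounds, a step that the two limits leave unreadable from compound 1 to compound 2, therefore cannot be read; all three values share (the limit of > 10 ug/mL in this assay, at which 3 of the 3 values shown sit), so nothing on the size or direction of any change in this assay can be taken from them.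

Compound 4 is `CCc1cccc2c(OC)c(-c3occ(C)c3CBr)ccc12`. It differs from compound 1 by bromomethyl in place of methylcarbamoyl on an aromatic carbon. Within the data shown here, no measured step concerns this group or its place on the shared core, and the step from compound 1 to compound 2 gives no size to lean on. The expectation for compound 4 therefore rests on the limit of compound 1 alone and is wide: compound 4 is estimated at 8 ug/mL, with a range from 1.5 ug/mL to 30 ug/mL, and the estimate corresponds to an at least 1.2-fold lower number from compound 1 to compound 4 (0.09 log units; that floor lies within the scatter) from compound 1, with a fair chance that only a limit is reported again.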

Compound 4, concentration for half-maximal effect: > 10 ug/mL
Compound 4: a limit, no number (the forecaster's own chance of this, stated with the estimate: 45%); middle value at least 1.2-fold (0.09 log units) from the limit.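

In this assay compound 4 gives > 10 ug/mL, a limit and not a number. The step between compound 1 and compound 4 therefore cannot be read, and no new step arises: the limit of > 10 ug/mL in this assay, at which 4 of the 4 values shown sit.

Still open, going by these compounds, is whether any group at this place on the shared core gives a readable number in this assay.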